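Aryl substituent rearrangement in the thioether series

A few compounds are considered here, and "the series" means these few. Any claim that something is new, unique, unknown or untested is made for them only; others in the source may bear on it.

Three members of the series have been measured in a functional assay on THP-1 cells (Homo sapiens); a lower number here means a smaller maximal response, a higher number a larger maximal response. Compound 1 `CC[C@H]1c2c(cc(F)c(F)c2O)[C@H](Nc2cccc3[nH]c(=O)ccc23)[C@@](O)(C(F)(F)F)C1OC` gives 78%. Compound 2 `CCSC[C@@](O)([C@@H](Nc1cccc2nc(C)ccc12)c1ccc(C)cc1)C(F)(F)F` gives 87%. Compound 3 `CCSC[C@@](O)([C@@H](Nc1cccc2nc(C)ccc12)c1cccc(F)c1OC)C(F)(F)F` gives 69%, the smallest of the three numbers; compound 1 lies within the scatter of it, while compound 2 stands beyond the scatter above it. Among the measured compounds shown here, the one single-point step measured so far, a number 18 percentage points lower from compound 2 to compound 3 (beyond the scatter), shows that exchanging the aryl group on this carbon can move the maximal response by a modest amount.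

Compound 4 `CCSC[C@@](O)([C@@H](Nc1cccc2nc(C)ccc12)c1ccc(OC)cc1F)C(F)(F)F` carries 2-fluoro-4-methoxyphenyl in place of 3-fluoro-2-methoxyphenyl on a saturated chain carbon bound to a nitrogen on an aromatic ring and a saturated chain carbon

For the measured compounds named here, no step involving 2-fluoro-4-methoxyphenyl has been measured, so the only guide is that the 3-fluoro-2-methoxyphenyl compound 3 sits below the 4-methylphenyl compound 2 by a number 18 percentage points lower from compound 2 to compound 3 (beyond the scatter). A rearranged aryl group is expected to give a number between those two, most likely within the scatter of compound 3. Compound 4 is therefore estimated at 76%, range 63% to 89%, a step of a number 7 percentage points higher from compound 3 to compound 4 (within the scatter) expected in this assay.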

Compound 4, largest response reached (Emax), in percent of the reference or control that the assay uses: 85%
Compound 4: the middle estimate sits 9 percentage points below what was measured; measured number inside the range.
By their numbers in this assay, from the lowest: compounds 3, 1, 4 and 2 (each within the scatter of the next, the first and the last beyond it).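

Swapping 3-fluoro-2-methoxyphenyl for 2-fluoro-4-methoxyphenyl, which joins the same atoms differently on the saturated chain carbon, changes the maximal response in this assay (a number 16 percentage points higher from compound 3 to compound 4 (beyond the scatter)). The lower number of compound 3 therefore does not extend to both fluoro-methoxy aryl groups shown here. The other new comparison (a number 2 percentage points lower from compound 2 to compound 4 (within the scatter)) leaves 3-fluoro-2-methoxyphenyl as the only one of the three aryl groups at this carbon set apart from the other two, and nothing available explains that difference.

Still open, on these data alone, is whether the fluorine or the methoxy placement accounts for the shift, which 2-fluorophenyl and 4-methoxyphenyl would help separate. Also open, as far as these compounds go, is how this position responds to a group of a different kind, such as an aminophenyl or a carboxyphenyl.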